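A few compounds are considered here, and "the series" means these few. Any claim that something is new, unique, unknown or untested is made for them only; others in the source may bear on it.

Of the compounds shown here, two have been measured so far in a functional assay on HL-60 cells (Homo sapiens) for inhibition, read by MTT assay, with a stated time of 48 h; on this read-out higher numbers stand for weaker inhibition and lower numbers for stronger inhibition. Compound 1 (`C[C@H]1CCC/C=C/[C@H]2CC[C@H](O)[C@@H](CC(=O)O1)O2`) gives 81200 nM, and compound 2 (`CO[C@H]1C=C[C@H]2C/C=C\C[C@H](c3ccc(Br)cc3)OC(=O)C[C@@H]1O2`) gives 10000 nM. Compound 2 therefore holds the lower of the two numbers, which means the stronger inhibition, and the gap between them lies beyond the usual scatter. Compound 3 (`CO[C@H]1C=C[C@H]2C/C=C\C[C@H](c3ccc(-c4ccccc4C(F)(F)F)cc3)OC(=O)C[C@@H]1O2`) keeps the core of compound 2 but carries 2-(trifluoromethyl)phenyl in place of bromo on an aromatic carbon, para to a large group: 2-(trifluoromethyl)phenyl in place of bromo on an aromatic carbon. Within the data shown here, no measured pair shows what a swap of this kind does in this assay, so the expectation stays cautious. The expected change is small and toward a lower number, a 1.4-fold lower number from compound 2 to compound 3 (0.15 log units; within the scatter), and no larger than the scatter. For compound 3 the estimated value is 7000 nM, with an expected range of 2000 nM to 25000 nM.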

Compound 3, half-maximal inhibitory concentration: 1100 nM
Beside the measured number, compound 3's estimate is 6.4-fold (0.80 log units) above it; the measured number lies below the stated range.
By their numbers in this assay, from the lowest: compound 3; then compound 2; then compound 1.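

In this assay, swapping bromo for 2-(trifluoromethyl)phenyl on this aromatic carbon, para to a large group, gives a 9.1-fold lower number from compound 2 to compound 3 (0.96 log units; beyond the scatter) and so means stronger inhibition. This is the first pair shown that differs in one place, and it shows that the position accepts a group of 10 heavy atoms, including a whole extra aromatic ring, where bromo has only 1, with the number falling rather than rising. Nothing at hand explains why the number falls.

On these data alone, it remains open whether the gain comes from the added aromatic ring alone or needs the trifluoromethyl group, which a plain phenyl at this place would help to separate. As far as these compounds go, it is equally open how this position would respond to a group of another kind, such as an amine or a carboxylic acid.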